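The compounds below may be only part of what the source reports. "The series", "measured", "known", "first", "only" and "open" are said of these compounds alone.

Working notes on the series. The shared core, seen in compound 1 `COc1ccc2nc(-c3n[nH]cc3/C=C/c3cccnc3)[nH]c2c1`, carries a hydrogen at the position in question; in a functional assay on A-375 cells (Homo sapiens) for antiproliferative activity (a higher number here means a weaker inhibitor, a lower number a stronger inhibitor), compound 1 gives 2500 nM. Compound 2 `COc1cncc(/C=C/c2c[nH]nc2-c2nc3ccc(OC)cc3[nH]2)c1` carries methoxy there, and in this assay compound 2 gives 910 nM, the lowest number among the three measured compounds. Compound 3 `COC(=O)c1cncc(/C=C/c2c[nH]nc2-c2nc3ccc(OC)cc3[nH]2)c1` carries methoxycarbonyl, and in this assay compound 3 gives 3100 nM. The measured steps are a 2.7-fold lower number from compound 1 to compound 2 (0.44 log units; beyond the scatter), a 3.4-fold higher number from compound 2 to compound 3 (0.53 log units; beyond the scatter) and a 1.2-fold higher number from compound 1 to compound 3 (0.09 log units; within the scatter).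

Compound 4 `CCNC(=O)c1cncc(/C=C/c2c[nH]nc2-c2nc3ccc(OC)cc3[nH]2)c1` is not yet measured. Relative to compound 2 the change is ethylcarbamoyl in place of methoxy on an aromatic carbon; the entering group shares a carbonyl with the methoxycarbonyl of compound 3. The step that bears most directly on this change is a 3.4-fold higher number from compound 2 to compound 3 (0.53 log units; beyond the scatter), where methoxy gave way to a carbonyl-bearing group. Going from hydrogen to methoxycarbonyl gave a 1.2-fold higher number from compound 1 to compound 3 (0.09 log units; within the scatter), a step within the scatter. Going by the values given here, no measured compound carries an amide, so the ethylcarbamoyl group itself is untested in this set. The expectation for compound 4 is therefore a modest rise in this assay, of about a 2.7-fold higher number from compound 2 to compound 4 (0.44 log units; beyond the scatter). Compound 4 is estimated at 2500 nM, with a range from 900 nM to 7000 nM.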

Compound 4, half-maximal inhibitory concentration: 3600 nM
Estimate against measurement, compound 4: 1.4-fold (0.16 log units) below, and the stated range covers the measured number.
By their numbers in this assay, from the lowest: compound 2; then compounds 1, 3 and 4 (each within the scatter of the next).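

In this assay ethylcarbamoyl in place of methoxy gives a 4.0-fold higher number from compound 2 to compound 4 (0.60 log units; beyond the scatter), so the rise seen with methoxycarbonyl at this position is not limited to that one group: a second carbonyl-bearing group, this time with the amide hydrogen and an ethyl chain, also stands apart from methoxy. Ethylamino in place of methoxy on the carbonyl carbon gives a 1.2-fold higher number from compound 3 to compound 4 (0.06 log units; within the scatter), and ethylcarbamoyl in place of hydrogen on the aromatic carbon gives a 1.4-fold higher number from compound 1 to compound 4 (0.16 log units; within the scatter), so the hydrogen, methoxycarbonyl and ethylcarbamoyl compounds cannot be told apart here, and among the four groups shown only the methoxy of compound 2 departs from hydrogen beyond the scatter. Nothing in the data at hand accounts for this result.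

Still open, from the compounds shown here alone, is whether a longer ether such as ethoxy, or a hydroxy group, would stay with compound 2 or fall in with the other three. Equally open, going by these compounds, is whether a carboxylic acid, an unsubstituted carboxamide or an amide with a longer chain on its nitrogen would differ from the ethylcarbamoyl of compound 4.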